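Fluoro addition on the aryl ring of compound 3

A few compounds are considered here, and "the series" means these few. Any claim that something is new, unique, unknown or untested is made for them only; others in the source may bear on it.

Compound 3 `COc1c(F)cccc1C1CCN(c2ccn3c(CC4CC4)nnc3c2Cl)CC1` gives 37 nM in a functional assay on CHO cells for agonist activity at metabotropic glutamate receptor 2 (Homo sapiens), read by scintillation counting and GTPgammaS binding, with a stated time of 30 min; on this read-out higher numbers stand for an effect only at larger amounts of compound and lower numbers for an effect already at smaller amounts. Among the compounds with values here, of the three numbers so far it is the second highest: compound 1 `Fc1ccc(C2CCN(c3ccn4c(CC5CC5)nnc4c3Cl)CC2)c(F)c1` gives 61.7 nM, and a 1.7-fold lower number from compound 1 to compound 3 (0.22 log units; within the scatter). Compound 2 `COc1cccc(F)c1C1CCN(c2ccn3c(CC4CC4)nnc3c2Cl)CC1` gives 6 nM, and a 6.2-fold higher number from compound 2 to compound 3 (0.79 log units; beyond the scatter). The largest step in the set is a 10-fold lower number from compound 1 to compound 2 (1.01 log units; beyond the scatter), a swap of the whole aryl substitution pattern.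

Compound 4 `COc1c(C2CCN(c3ccn4c(CC5CC5)nnc4c3Cl)CC2)ccc(F)c1F` differs from compound 3 by fluoro in place of hydrogen on an aromatic carbon, ortho to the fluoro group already present and meta to the methoxy group. Within the data shown here, none of the measured steps is a single added fluoro; each of them exchanges both substituents of the aryl ring at once, so no step bears directly on this change. Among the measured compounds shown here, the only hint is that compound 1, carrying a 2,4-difluorophenyl, lies within the scatter of compound 3, which speaks against a large move in either direction. A step in this assay no larger than the scatter is therefore expected, with the direction left open.

For compound 4 the estimate in this assay is 40 nM, within 15 nM to 110 nM, which means an expected 1.1-fold higher number from compound 3 to compound 4 (0.03 log units; within the scatter).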

Compound 4, half-maximal effective concentration: 26 nM
For compound 4 the middle estimate is 1.5-fold (0.19 log units) above the measured one; the measured number falls inside the stated range.
By their numbers in this assay, from the lowest: compound 2; then compounds 4, 3 and 1 (each within the scatter of the next, the first and the last beyond it).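

In this assay the series now holds its first single added fluoro (a 1.4-fold lower number from compound 3 to compound 4 (0.15 log units; within the scatter)), so on the 3-fluoro-2-methoxyphenyl ring, fluoro in place of hydrogen at this position, ortho to a fluoro group and meta to a methoxy group, gives a step that cannot be told from the scatter. The 3,4-difluoro-2-methoxyphenyl ring remains apart from the 2-fluoro-6-methoxyphenyl ring (a 4.3-fold higher number from compound 2 to compound 4 (0.64 log units; beyond the scatter)), and it now also separates from the 2,4-difluorophenyl ring (a 2.4-fold lower number from compound 1 to compound 4 (0.38 log units; beyond the scatter)), a step beyond the scatter, even though the 3-fluoro-2-methoxyphenyl ring stood within the scatter of that same ring. No measurement shown here accounts for these numbers.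

Fluoro is the only group shown at this position, so it remains open whether chloro, a nitrile, an amine or a carboxylic acid there would also stay within the scatter. From the compounds shown here alone, it is also open whether the same added fluoro would behave in the same way on the 2-fluoro-6-methoxyphenyl ring, which has the lowest number of the set.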